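The source may report more compounds than this note shows. Statements on the series, on what has been measured and on what is new or still open speak of the compounds shown alone.

Three compounds here share one core and are compared in a functional assay on HeLa cells (Homo sapiens) for antiproliferative activity, read by CCK-8 assay, with a stated time of 72 h, tested at 2 uM; on this read-out higher numbers stand for a stronger effect at the one concentration tested and lower numbers for a weaker effect. Compound 3 `Nc1ccccc1NC(=O)c1ccc(CSC(=S)N2CCN(c3ccccc3F)CC2)cc1` gives 17.5% in this assay. Compound 1 `Nc1ccccc1NC(=O)c1ccc(CSC(=S)N2CCCc3ccccc32)cc1` gives 26.1%, which lies within the scatter of compound 3. Compound 2 `CN(Cc1ccncc1)C(=S)SCc1ccc(C(=O)Nc2ccccc2N)cc1` gives 29.5%, a gap beyond the scatter from compound 3. Among the measured compounds shown here, the only measured step, a number 3.4 percentage points higher from compound 1 to compound 2 (within the scatter), swaps the group on the thiocarbonyl carbon and stays within the scatter. Compound 4 `CN1CCN(C(=S)SCc2ccc(C(=O)Nc3ccccc3N)cc2)CC1` differs from compound 3 by methyl in place of 2-fluorophenyl on an amine nitrogen in a ring. For the measured compounds named here, no measured step touches this ring nitrogen, so the one step gives only weak guidance; since it was within the scatter, a step of about a number 2.5 percentage points higher from compound 3 to compound 4 (within the scatter) is expected, none beyond the scatter. Compound 4 is estimated at 20%, between 8% and 33%.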

Compound 4, a percentage reported as inhibition, at one concentration (the size of the read-out at that concentration, not a potency): 52.6%
Compound 4: middle estimate off by 32.6 percentage points, on the low side; the whole stated range lies below it.
By their numbers in this assay, from the lowest: compounds 3, 1 and 2 (each within the scatter of the next, the first and the last beyond it); then compound 4.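

Among the compounds shown here, putting methyl in place of 2-fluorophenyl on the ring nitrogen gives a number 35.1 percentage points higher from compound 3 to compound 4 (beyond the scatter), showing that the group on this nitrogen can move the read-out far more than the one earlier step did. The 4-methylpiperazin-1-yl group on the thiocarbonyl carbon also outperforms the two other groups there, with a number 23.1 percentage points higher from compound 2 to compound 4 (beyond the scatter) and a number 26.5 percentage points higher from compound 1 to compound 4 (beyond the scatter). Nothing available explains these rises. Still open, going by these compounds, is whether a hydrogen, an ethyl group or an unsubstituted phenyl group on this ring nitrogen would give a number close to that of methyl or of 2-fluorophenyl.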